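This account rests on a few compounds, and the source may have more. Where it says the series, first, only, none or still open, it means among the compounds named here.

Measured in a functional assay on CCRF-CEM cells (Homo sapiens) for antiproliferative activity, read by trypan blue exclusion, with a stated time of 72 h; a higher number here means a weaker inhibitor, a lower number a stronger inhibitor:

- Compound 1 `Cc1c(NC(=O)C(C)Br)cccc1C(=O)NC(N)=O`: 480 nM
- Compound 2 `NC(=O)NC(=O)c1cc(NC(=O)CBr)ccc1Cl`: 540 nM
- Compound 3 `NC(=O)NC(=O)c1ccc(O)c(NC(=O)CBr)c1`: > 20000 nM ( a limit of the assay, not a number )

In this assay compound 1 gives 480 nM and compound 2 gives 540 nM, so the two lie within the usual scatter of each other. The value for compound 3 is a limit, > 20000 nM.

Compound 4 `Cc1c(NC(=O)CCl)cccc1C(=O)NC(N)=O` has not yet been measured. It differs from compound 1 in one place, (chloromethyl in place of 1-bromoethyl on a carbonyl carbon), with chloromethyl in place of 1-bromoethyl on a carbonyl carbon.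

For the measured compounds named here, no two measured compounds differ in one place only, so the data give no direct size for this change. A moderate shift towards a higher number is expected in this assay, meaning a weaker inhibitor. The expected step is a 3.1-fold higher number from compound 1 to compound 4 (0.49 log units; beyond the scatter). The upper end of the range is kept wide because of the limit of > 20000 nM in this assay, at which 1 of the 3 values shown sits. For compound 4 the estimated value is 1500 nM, with an expected range of 350 nM to 8000 nM.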

Compound 4, half-maximal inhibitory concentration: 2700 nM
Estimate against measurement, compound 4: 1.8-fold (0.26 log units) below; the range from low to high includes it.
By their numbers in this assay, from the lowest: compounds 1 and 2 (each within the scatter of the next); then compound 4. At a limit, above all of these: compound 3.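

For the compounds shown here, the change from 1-bromoethyl to chloromethyl on a carbonyl carbon now has a direct size, which the earlier compounds could not give: in this assay it brings a 5.6-fold higher number from compound 1 to compound 4 (0.75 log units; beyond the scatter). This shows that the group on this carbonyl carbon affects the read-out, and that this change takes the number beyond the scatter in the direction of a weaker inhibitor. The compounds shown offer no measurement that explains the step.

The change replaces bromine with chlorine and shortens the group at the same time, so this single pair cannot separate the two contributions. Bromomethyl and 1-chloroethyl would each isolate one of them, and it remains open how a longer chain or an amine would read at this place.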